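This account rests on a few compounds, and the source may have more. Where it says the series, first, only, none or still open, it means among the compounds named here.

Compound 1, `CCN(CC)c1cc(C)nc(N(CC)c2c(Br)cc(C(C)C)cc2SC)n1`, gives 26 nM in an assay on isolated protein for binding affinity to corticotropin-releasing factor receptor 1 (Homo sapiens); a higher number here means a weaker inhibitor, a lower number a stronger inhibitor.
Compound 2, `CCN(CC)c1cc(C)nc(N(CC)c2ccc(N(C)C)cc2C(F)(F)F)n1`, gives 11 nM in this assay.
Compound 3, `CCN(c1nc(C)cc(C)n1)c1c(Br)cc(C(C)C)cc1SC`, gives 51 nM in this assay.

Compounds 1 and 3 share one core and differ in a single place: methyl in place of diethylamino on an aromatic carbon. This change moved the number by a 2.0-fold higher number from compound 1 to compound 3 (0.29 log units; within the scatter). Compound 2 is built on a different core; how its core differs from that of compound 1 is not broken down here. Among the three measured compounds, compound 2 has the lowest number in this assay, and its gap to compound 1 and to compound 3 lies beyond the usual scatter, so it is the strongest binder of the three.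

Compound 4, `CCN(c1nc(C)cc(C)n1)c1ccc(N(C)C)cc1C(F)(F)F`, has not yet been measured. It stands to compound 2 as compound 3 stands to compound 1: methyl in place of diethylamino on an aromatic carbon. The surroundings of the changed position are the same in both pairs, so this is the same change, made a second time on the other core. For the measured compounds named here, because the earlier instance of the change gave a 2.0-fold higher number from compound 1 to compound 3 (0.29 log units; within the scatter), a step of about the same size is expected here, a 2.0-fold higher number from compound 2 to compound 4 (0.30 log units; within the scatter), with the reservation that a single earlier pair is the only guide. Compound 4 is therefore estimated at 22 nM in this assay, most likely between 10 nM and 50 nM.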

Compound 4, inhibition constant: 68 nM
Estimate against measurement, compound 4: 3.1-fold (0.49 log units) below; measured number above the stated range.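

On the core of compound 2, putting methyl in place of diethylamino gives a 6.2-fold higher number from compound 2 to compound 4 (0.79 log units; beyond the scatter), a real weakening of binding in this assay, whereas the same change on the core of compound 1 stays within the scatter. The change therefore does not carry over from one core to the other at a constant size, so a step measured on one core is a poor stand-in for the step on the other: the same change on two cores in this assay, a 2.0-fold higher number (0.29 log units; within the scatter) from compound 1 to compound 3 and a 6.2-fold higher number (0.79 log units; beyond the scatter) from compound 2 to compound 4, 3.2-fold (0.50 log units) apart, beyond the scatter of two such steps

For the compounds shown here, this comparison rests on only two pairs, and it shows that the core matters without showing which part of it does or why, as the two cores differ in more than one place and those differences are not taken apart here.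

The compounds shown leave open whether an intermediate group in place of diethylamino, such as a smaller amine like ethylamino or a ring amine like pyrrolidine, would give a number nearer that of compound 2 or that of compound 4. They also leave open how this change behaves on further cores, for example one that carries a chlorine or a methoxy group on the aromatic ring that bears the other substituents.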